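Pyridine to cyclobutyl at the amide of compound 2

The source may hold more compounds than are shown below. What is called first, only, known or untested is meant among the compounds shown, and "the series" means these compounds.

Measured in an in vitro functional assay on CHO/Galpha16 cells for antagonist activity at C-C chemokine receptor type 8 (Homo sapiens), read by FLIPR; on this read-out lower numbers stand for stronger inhibition and higher numbers for weaker inhibition:
- compound 1, `CCCC(=O)N1CCC(NS(=O)(=O)c2ccc(NC(=O)c3ccoc3)c3ccccc23)CC1`, gives 1520 nM
- compound 2, `CCCC(=O)N1CCC(NS(=O)(=O)c2ccc(NC(=O)c3cccnc3)c3ccccc23)CC1`, gives 885 nM

For the measured compounds named here, compound 2 has the lower of the two numbers, yet the only measured step, a 1.7-fold lower number from compound 1 to compound 2 (0.23 log units; within the scatter), lies within the scatter, so the two compounds cannot be told apart on these data. Compound 3, `CCCC(=O)N1CCC(NS(=O)(=O)c2ccc(NC(=O)C3CCC3)c3ccccc23)CC1`, differs from compound 2 by cyclobutyl in place of pyridin-3-yl on a carbonyl carbon. Going by the values given here, the one measured step exchanged one aromatic ring for another on the same carbonyl carbon and changed little; no measured step replaces an aromatic ring with a saturated carbon ring, so it only loosely bears on this change. Without direct precedent, the expected step is none beyond the scatter, with a wide range around it. Compound 3 is therefore estimated at 1000 nM, between 350 nM and 3000 nM, which corresponds to an expected 1.1-fold higher number from compound 2 to compound 3 (0.05 log units; within the scatter).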

Compound 3, half-maximal inhibitory concentration: 57.9 nM
Beside the measured number, compound 3's estimate is 17-fold (1.24 log units) above it; measured number below the stated range.
By their numbers in this assay, from the lowest: compound 3; then compounds 2 and 1 (each within the scatter of the next).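

In this assay, this position proves far more sensitive than the first two compounds suggested: exchanging one aromatic ring for another on the carbonyl carbon made no clear difference, whereas cyclobutyl gives a 15-fold lower number from compound 2 to compound 3 (1.18 log units; beyond the scatter) and a 26-fold lower number from compound 1 to compound 3 (1.42 log units; beyond the scatter). Compound 3 is therefore the most potent of the three, and what separates it from the others is a saturated carbon ring in place of an aromatic one. Nothing shown here accounts for the size of this gain.

With only one saturated ring among these compounds, it remains open whether cyclobutyl itself matters or whether cyclopropyl, cyclohexyl or an open chain such as isopropyl would serve equally well. As far as these compounds go, how an amine carried on the cyclobutyl ring would read also remains open.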